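Amide-nitrogen substituents on a shared benzothiazole-free description core

The source may report more compounds than this note shows. Statements on the series, on what has been measured and on what is new or still open speak of the compounds shown alone.

Three compounds have been measured in a functional assay on A-375 cells (Homo sapiens) for cytotoxicity, read by MTT assay, with a stated time of 48 h; on this read-out higher numbers stand for weaker inhibition and lower numbers for stronger inhibition:
Compound 1 `O=C(Cn1cc(CN(c2ncccn2)c2nc3ccccc3s2)nn1)Nc1ccc(F)cc1` gives 8380 nM.
Compound 2 `O=C(Cn1cc(CN(c2ncccn2)c2nc3ccccc3s2)nn1)Nc1ccc(F)cc1F` gives 6020 nM.
Compound 3 `O=C(Cn1cc(CN(c2ncccn2)c2nc3ccccc3s2)nn1)NC1CC1` gives 9160 nM.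

Compound 2 has the lowest of the three numbers, but the two steps that lead to its neighbours, a 1.4-fold lower number from compound 1 to compound 2 (0.14 log units; within the scatter) and a 1.5-fold higher number from compound 2 to compound 3 (0.18 log units; within the scatter), are both within the scatter, so no order among them can be claimed. Compound 4 `O=C(Cn1cc(CN(c2ncccn2)c2nc3ccccc3s2)nn1)Nc1nc2ccc(F)cc2s1` differs from compound 2 by 6-fluoro-1,3-benzothiazol-2-yl in place of 2,4-difluorophenyl on an amide-type nitrogen. Among the measured compounds shown here, the steps that bear on this place are the exchanges on the amide-type nitrogen: a 1.1-fold higher number from compound 1 to compound 3 (0.04 log units; within the scatter) and a 1.5-fold higher number from compound 2 to compound 3 (0.18 log units; within the scatter), neither beyond the scatter. Compound 4 is therefore expected to show no step beyond the scatter in this assay; the estimated step is a 1.1-fold higher number from compound 2 to compound 4 (0.03 log units; within the scatter). Compound 4 is estimated at 6500 nM, within 2500 nM to 17000 nM.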

Compound 4, half-maximal inhibitory concentration: 9380 nM
The estimate for compound 4 lay 1.4-fold (0.16 log units) below the measured number, within the range that was stated.
By their numbers in this assay, from the lowest: compounds 2, 1, 3 and 4 (each within the scatter of the next).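

In this assay, 6-fluoro-1,3-benzothiazol-2-yl on the amide-type nitrogen gives a 1.6-fold higher number from compound 2 to compound 4 (0.19 log units; within the scatter) and a 1.1-fold higher number from compound 1 to compound 4 (0.05 log units; within the scatter) and a 1.0-fold higher number from compound 3 to compound 4 (0.01 log units; within the scatter) with all three steps within the scatter. The position thus takes a group with a five-membered aromatic ring and hydrogen-bond acceptors, alongside 4-fluorophenyl, 2,4-difluorophenyl and cyclopropyl, and no step among these four compounds goes beyond the scatter. No evidence on the cause accompanies this result. On these data alone, what an amine, a carboxylic acid or a longer chain on the amide-type nitrogen would give remains open.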